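The source may hold more compounds than are shown below. What is called first, only, known or untested is meant among the compounds shown, and "the series" means these compounds.

Measured in a functional assay on BGC-823 cells (Homo sapiens) for antiproliferative activity, read by MTT assay, with a stated time of 48 h (on this read-out higher numbers stand for weaker inhibition and lower numbers for stronger inhibition), so far:
- compound 1, `Cc1ccc(N2CCN(Cn3nc(-c4ccc5c(c4)OCCO5)oc3=S)CC2)c(C)c1`: 28300 nM
- compound 2, `Fc1ccccc1N1CCN(Cn2nc(-c3ccc4c(c3)OCCO4)oc2=S)CC1`: > 50000 nM

Compound 2 stands only at a limit of this assay, not at a number; it sits at the limit of > 50000 nM in this assay, at which 1 of the 2 values shown sits. Among the measured compounds shown here, the one step, an at least 1.7-fold higher number from compound 1 to compound 2 (0.24 log units; that floor lies within the scatter), is itself only a floor, and that floor lies within the scatter, so no direction of change on this aryl group is established.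

Compound 3 is `S=c1oc(-c2ccc3c(c2)OCCO3)nn1CN1CCN(c2cccc(Cl)c2Cl)CC1`. Its change from compound 2: 2,3-dichlorophenyl in place of 2-fluorophenyl on an amine nitrogen in a ring. For the measured compounds named here, only the step from compound 1 to compound 2 bears on an exchange at this position, and it showed no movement beyond the scatter. For compound 3 no shift beyond the scatter is therefore expected in this assay, and a second limit is a real possibility; the estimated step is an at least 1.1-fold lower number from compound 2 to compound 3 (0.04 log units; that floor lies within the scatter). Compound 3 is expected near 45000 nM, in the range 15000 nM to 120000 nM.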

Compound 3, half-maximal inhibitory concentration: 22600 nM
Beside the measured number, compound 3's estimate is 2.0-fold (0.30 log units) above it; low and high end bracket the measured number.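

In this assay, among the compounds shown here, the exchange at this aryl group gives the first step at this position that clears the scatter, with an at least 2.2-fold lower number from compound 2 to compound 3 (0.34 log units; beyond the scatter). That step is only a floor, since compound 2 stands at a limit and not at a number: the limit of > 50000 nM in this assay, at which 1 of the 3 values shown sits. Meanwhile 2,3-dichlorophenyl and 2,4-dimethylphenyl are not separated, with a 1.3-fold lower number from compound 1 to compound 3 (0.10 log units; within the scatter), so 2-fluorophenyl is set apart from 2,3-dichlorophenyl only, while its floor against 2,4-dimethylphenyl stays within the scatter.

Open, as far as these compounds go, is whether the separation from 2-fluorophenyl follows the chlorine atoms or any second group on the phenyl ring, which a phenyl carrying one chlorine or one methyl would test. Also open, from the compounds shown here alone, is how a methoxyphenyl, a pyridyl or a benzyl group on the same amine nitrogen would read in this assay.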